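This account rests on a few compounds, and the source may have more. Where it says the series, first, only, none or still open, it means among the compounds named here.

Measured compounds:
Compound 1, `C[C@H](NC(=O)[C@]1(Cc2ccccc2)CCN1C(=O)OCc1ccccc1)C(=O)N(C)C`, gives > 100000 nM in an ADME assay on HELF cells (Homo sapiens) for cytotoxicity, with a stated time of 3 days (on this read-out higher numbers stand for lower toxicity in this test and lower numbers for higher toxicity in this test), which is a limit of the assay and not a number.
Compound 2, `C[C@H](NC(=O)[C@]1(Cc2ccccc2)CCN1S(=O)(=O)c1ccc2ccccc2c1)C(N)=O`, gives > 100000 nM in this assay, again a limit.
Compound 3, `NC(=O)[C@H](CCC(=O)O)NC(=O)C1(Cc2ccccc2)CCN1C(=O)OCc1ccccc1`, gives > 100000 nM in this assay, again a limit.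

Compound 1 therefore stands at the top of what the assay reports, as do the other two: the limit of > 100000 nM in this assay, at which 3 of the 3 values shown sit. Among the compounds with values here, no step between measured compounds is available to guide an expectation. Compound 4, `C[C@H](NC(=O)[C@]1(Cc2ccccc2)CCN1C(=O)OCc1ccccc1)C(=O)NCc1ccccc1`, differs from compound 1 as follows: benzylamino in place of dimethylamino on a carbonyl carbon. Within the data shown here, with no measured step to go on, compound 4 is expected to remain at the limit like compound 1, with an expected step of a number no higher from compound 1 to compound 4 (the limit leaves the size open), that is none beyond the scatter. The estimate for compound 4 is 100000 nM, between 30000 nM and 300000 nM.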

Compound 4, half-maximal cytotoxic concentration: 42000 nM
The estimate for compound 4 lay 2.4-fold (0.38 log units) above the measured number; low and high end bracket the measured number.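

Benzylamino in place of dimethylamino on a carbonyl carbon gives an at least 2.3-fold lower number from compound 1 to compound 4 (0.37 log units; beyond the scatter) in this assay, so a change at this position can move the read-out towards higher toxicity in this test. The full size of the step stays open because compound 1 stands at a limit and not at a number: the limit of > 100000 nM in this assay, at which 3 of the 4 values shown sit.

As far as these compounds go, it remains open whether the six-membered aromatic ring or the amide hydrogen goes with this step. Methylamino, which keeps that hydrogen without the ring, or phenethylamino, with a longer chain, could separate the two.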